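From methyl to butyl: compound 3 and compound 4

This account rests on a few compounds, and the source may have more. Where it says the series, first, only, none or still open, it means among the compounds named here.

In an ADME assay on SW1353 cells (Homo sapiens) for cytotoxicity, read by a luciferase reporter, with a stated time of 30 min (on this read-out higher numbers stand for lower toxicity in this test and lower numbers for higher toxicity in this test), compound 1 `Cc1cc(Cl)ccc1-c1ccc(C(=O)Nc2ccc(N3CCNCC3)cc2)o1` gives 8800 nM. For compound 2 `O=C(Nc1ccc(N2CCNCC2=O)cc1)c1ccc(-c2ccc(Cl)cc2)o1` the result is "not determined" (no result reported). Compound 3 `CN(C(=O)c1ccc(-c2ccc(Cl)cc2)o1)c1ccc(N2CCNCC2)cc1` gives > 20000 nM, which is a limit of the assay and not a number. Compound 3 thus stands at the limit of > 20000 nM in this assay, at which 1 of the 3 values shown sits. Compound 4 `CCCCN(C(=O)c1ccc(-c2ccc(Cl)cc2)o1)c1ccc(N2CCNCC2)cc1` carries propyl in place of hydrogen on a saturated chain carbon bound to an amide-type nitrogen. Cut one bond further out, the same difference reads methyl to butyl. Within the data shown here, no measured pair shows this kind of change, and the expectation is therefore loose. A modest step towards lower numbers, meaning higher toxicity in this test, is expected, with an estimated size of an at least 1.3-fold lower number from compound 3 to compound 4 (0.12 log units; that floor lies within the scatter). Compound 4 is expected at 15000 nM, with an estimated range from 6000 nM to 30000 nM.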

Compound 4, half-maximal cytotoxic concentration: 19000 nM
The estimate for compound 4 lay 1.3-fold (0.10 log units) below the measured number; the range from low to high includes it.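

Among these compounds, with an at least 1.0-fold lower number from compound 3 to compound 4 (0.02 log units; that floor lies within the scatter), this is the first reading of propyl in place of hydrogen on a saturated chain carbon bound to an amide-type nitrogen in this assay. Compound 4 gives a single number, so this position can carry butyl and still yield a measured value. For compound 3 the value is a limit of the assay and not a number: the limit of > 20000 nM in this assay, at which 1 of the 4 values shown sits.

On these data alone, what a longer chain than butyl, an amine or a carboxylic acid would give at this place stays open.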